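Naphthyloxyacetyl hydrazones: cytotoxicity note ahead of compound 3

The source may report more compounds than this note shows. Statements on the series, on what has been measured and on what is new or still open speak of the compounds shown alone.

Measured so far:
compound 1 `O=C(COc1cccc2ccccc12)N/N=C/c1cccc(O)c1` gives 32.6 ug/mL in an ADME assay on MT4 cells (Homo sapiens) for cytotoxicity, read by MTT assay, with a stated time of 4 days; a lower number here means that less compound is tolerated, a higher number that more compound is tolerated
compound 2 `O=C(COc1cccc2ccccc12)N/N=C/c1ccccc1Br` gives 11.4 ug/mL in this assay

Among the compounds with values here, compound 2 holds the lowest of the two numbers in this assay; its only neighbour is compound 1, and the step of a 2.9-fold lower number from compound 1 to compound 2 (0.46 log units; beyond the scatter) lies beyond the scatter. Compound 3 `O=C(COc1cccc2ccccc12)N/N=C/c1ccccc1O` differs from compound 2 in one place: hydroxy in place of bromo on an aromatic carbon. Within the data shown here, the single measured step that bears on this is a 2.9-fold lower number from compound 1 to compound 2 (0.46 log units; beyond the scatter), in which hydroxy gave way to bromo while the substituent also moved to sit ortho to a large group. Compound 3 reverses the bromo-for-hydroxy part of that step and keeps the substituent where it is in compound 2, so a partial return toward the number of compound 1 is expected rather than the full reversal. On that basis compound 3 is expected to show a 2.1-fold higher number from compound 2 to compound 3 (0.32 log units; beyond the scatter) in this assay. The estimate for compound 3 is 24 ug/mL, with a range of 12 ug/mL to 50 ug/mL.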

Compound 3, half-maximal cytotoxic concentration: 5.19 ug/mL
Beside the measured number, compound 3's estimate is 4.6-fold (0.67 log units) above it; measured number outside the range, below it.
By their numbers in this assay, from the lowest: compound 3; then compound 2; then compound 1.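

Holding the place ortho to a large group fixed, hydroxy in place of bromo gives a 2.2-fold lower number from compound 2 to compound 3 (0.34 log units; beyond the scatter) in this assay. Keeping hydroxy and changing only its place, 2-hydroxyphenyl in place of 3-hydroxyphenyl gives a 6.3-fold lower number from compound 1 to compound 3 (0.80 log units; beyond the scatter), which separates the place of the hydroxy from the identity of the group, two changes that the earlier step had mixed. No supporting measurement explains these numbers.

Going by these compounds, whether an amine or a methoxy group on the same carbon would track hydroxy or bromo stays open. Also open, on these data alone, is the number bromo would give on the carbon that carries hydroxy in compound 1.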